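Compound 2 to compound 3: aryl swap at the limit

The source may hold more compounds than are shown below. What is called first, only, known or untested is meant among the compounds shown, and "the series" means these compounds.

In a physicochemical assay for lipophilicity (a higher number here means a more lipophilic compound, a lower number a more polar compound), compound 1 (`CCCS(=O)(=O)N1CCC(CNC(=O)C2CC2)(C(=O)N2CCOCC2)CC1`) gives < 1.4, which is a limit. Compound 2 (`CCCS(=O)(=O)N1CCC(CNC(=O)c2ccc(F)cc2C(F)(F)F)(C(=O)N2CCOCC2)CC1`) gives < 1.4, which is also a limit. Among the measured compounds shown here, the one measured step, a step that the two limits leave unreadable from compound 1 to compound 2, has no readable size. All that the series shows so far is the limit of < 1.4 in this assay, at which 2 of the 2 values shown sit.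

Compound 3 (`CCCS(=O)(=O)N1CCC(CNC(=O)c2ccccc2OC(F)(F)F)(C(=O)N2CCOCC2)CC1`) differs from compound 2 on a carbonyl carbon whose other neighbour is an amide-type nitrogen: 2-(trifluoromethoxy)phenyl in place of 4-fluoro-2-(trifluoromethyl)phenyl on a carbonyl carbon. Both groups carry one six-membered aromatic ring of carbon only and no net charge.

No step beyond the scatter is expected in this assay, and the data give no direction. For the measured compounds named here, the only guide is the limit of compound 2, < 1.4. The estimated step, a step that the limit leaves unreadable from compound 2 to compound 3, stays within the scatter. Compound 3 is estimated at 1.3, with an expected range of 0.9 to 1.7, and may again be reported only as a limit.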

Compound 3, partition coefficient: < 1.4
Compound 3 ended at the assay's limit; the forecaster's own chance of this, stated with the estimate: 70%; the middle value does not contradict the limit.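

No step can be read among compound 1, compound 2 and compound 3 in this assay, since each value is only a limit: the limit of < 1.4 in this assay, at which 3 of the 3 values shown sit.

The compounds shown leave open whether the groups on the carbonyl carbon differ at all in this assay, and by how much.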